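Swapping a fluorine for a nitrile on the benzyl arm

A few compounds are considered here, and "the series" means these few. Any claim that something is new, unique, unknown or untested is made for them only; others in the source may bear on it.

Three measured compounds share one core and differ only in the aromatic ring that hangs from a saturated chain carbon bound to an aromatic nitrogen. Compound 1 `O=c1ccoc2cc(OCc3cn(Cc4cccc(F)c4)nn3)ccc12` carries 3-fluorophenyl there; in a functional assay on A549 cells (Homo sapiens) for cytotoxicity, read by MTT assay, with a stated time of 48 h (a lower number here means a stronger inhibitor, a higher number a weaker inhibitor), compound 1 reaches only the limit > 100000 nM. Compound 2 `O=c1ccoc2cc(OCc3cn(Cc4ccc(F)cc4)nn3)ccc12` carries 4-fluorophenyl, and in this assay compound 2 likewise stops at the limit > 100000 nM. Within the data shown here, compound 3 `O=c1ccoc2cc(OCc3cn(Cc4ccccc4F)nn3)ccc12` carries 2-fluorophenyl, and in this assay compound 3 gives 10800 nM, the only real number among the three. Accordingly an at least 9.2-fold lower number from compound 1 to compound 3 (0.96 log units; beyond the scatter) and an at least 9.2-fold lower number from compound 2 to compound 3 (0.96 log units; beyond the scatter) are both at least modest, whereas a step that the two limits leave unreadable from compound 1 to compound 2 cannot be sized because the limit of > 100000 nM in this assay, at which 2 of the 3 values shown sit, hides both of its ends.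

Compound 4 `N#Cc1ccc(Cn2cc(COc3ccc4c(=O)ccoc4c3)nn2)cc1` differs from compound 3 by 4-cyanophenyl in place of 2-fluorophenyl on a saturated chain carbon bound to an aromatic nitrogen. Among the measured compounds shown here, no measured step involves a nitrile, so the nearest guide is the name of the group: 4-cyanophenyl resembles the 4-fluorophenyl of compound 2 more than the 2-fluorophenyl of compound 3, and every move away from 2-fluorophenyl in these data raised the number. A rise is therefore expected, of about a 5.6-fold higher number from compound 3 to compound 4 (0.74 log units; beyond the scatter), with a real chance that only a limit is reported. Compound 4 is estimated at 60000 nM, within 8000 nM to 300000 nM.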

Compound 4, half-maximal inhibitory concentration: > 100000 nM
Compound 4: a limit, no number; the forecaster's own chance of this, stated with the estimate: 50%; middle value at least 1.6-fold (0.22 log units) away from the limit.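

The earlier compounds shown here contrasted only the place of a fluorine on the benzyl ring, whereas here, in this assay an arm without any fluorine also falls short of the 2-fluorobenzyl arm, with an at least 9.2-fold higher number from compound 3 to compound 4 (0.96 log units; beyond the scatter) showing that change. Among these compounds, compound 3 therefore remains the only one of the four compounds with a real number, and none goes against this, so the 2-fluorobenzyl arm stands apart from a different group as well as from a moved fluorine. The steps to compound 4 from compound 1 and from compound 2, including cyano in place of fluoro on an aromatic carbon, cannot be read, because both ends of each step are limits and not numbers: the limit of > 100000 nM in this assay, at which 3 of the 4 values shown sit.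

From the compounds shown here alone, whether compound 3 owes its number to the fluorine itself or to any group placed as in the 2-fluorobenzyl arm stays open, and a 2-chlorophenyl or 2-cyanophenyl arm on that saturated chain carbon would speak to this. Also open, going by these compounds, is whether any arm can give a lower number than compound 3 at 10800 nM and whether a plain phenyl ring gives a number at all.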